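Methyl on the pendant phenyl: notes toward compound 4

The compounds below may be only part of what the source reports. "The series", "measured", "known", "first", "only" and "open" are said of these compounds alone.

The shared core is carried by compound 1 `COc1cc(-c2cccc3nc(-c4ccccc4)oc23)cc(OC)c1OC`, compound 2 `COc1ccc(-c2nc3cccc(-c4cc(OC)c(OC)c(OC)c4)c3o2)cc1F`, compound 3 `COc1cc(-c2cccc3nc(-c4cccc(Cl)c4)oc23)cc(OC)c1OC` and the not yet measured compound 4 `COc1cc(-c2cccc3nc(-c4ccc(C)cc4)oc23)cc(OC)c1OC`. In a functional assay on U-251 cells (Homo sapiens) for antiproliferative activity, read by MTT assay, with a stated time of 48 h (on this read-out lower numbers stand for stronger inhibition and higher numbers for weaker inhibition), compound 1 gives 3500 nM, the second highest of the three numbers; compound 2 gives 1700 nM and compound 3 gives 18500 nM. Two measured steps start from compound 1: a 2.1-fold lower number from compound 1 to compound 2 (0.31 log units; beyond the scatter), and a 5.3-fold higher number from compound 1 to compound 3 (0.72 log units; beyond the scatter). Between the two substituted analogues, an 11-fold higher number from compound 2 to compound 3 (1.04 log units; beyond the scatter).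

Compound 4 differs from compound 1 by methyl in place of hydrogen on an aromatic carbon. The step to compound 3 shows that a chloro added to this ring can raise the number well beyond the scatter, while the step to compound 2 shows that substitution on the same ring can also lower it. For the measured compounds named here, neither step carries a methyl, and no measured compound carries a group in the place now filled. The expectation is therefore a step of uncertain direction, most likely small: the expected step is a 1.2-fold lower number from compound 1 to compound 4 (0.07 log units; within the scatter). Compound 4 is estimated at 3000 nM in this assay, within 1000 nM to 9000 nM.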

Compound 4, half-maximal inhibitory concentration: 3200 nM
Compound 4: the middle estimate sits 1.1-fold (0.03 log units) below what was measured; measured number inside the range.
By their numbers in this assay, from the lowest: compounds 2, 4 and 1 (each within the scatter of the next, the first and the last beyond it); then compound 3.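

In this assay, adding methyl on an aromatic carbon para to a large group leaves the number unchanged within the scatter (a 1.1-fold lower number from compound 1 to compound 4 (0.04 log units; within the scatter)), so this change, unlike the chloro of the 3-chlorophenyl group, carries no measurable penalty. Set against the 3-chlorophenyl group, the 4-methylphenyl group stands clearly apart (a 5.8-fold lower number from compound 3 to compound 4 (0.76 log units; beyond the scatter)). Set against the 3-fluoro-4-methoxyphenyl group, it stays inside the scatter (a 1.9-fold higher number from compound 2 to compound 4 (0.27 log units; within the scatter)), so among the substituted pendant rings shown, only the 3-chlorophenyl group goes with a clearly raised number.

Nothing on hand explains why the methyl changes so little. Open questions are whether a chloro para to a large group would match the methyl or the 3-chlorophenyl group, and whether an amine or a carboxylic acid there would keep the number in this range.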